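The source may report more compounds than this note shows. Statements on the series, on what has been measured and on what is new or still open speak of the compounds shown alone.

Measured in a functional assay on A549 cells (Homo sapiens) for inhibition, read by sulforhodamine B assay, with a stated time of 48 h, tested at 50 uM; a lower number here means less inhibition of growth, a higher number more inhibition of growth at the concentration tested:
compound 1 `COc1ccc([C@@H]2CC(=O)c3cc(CC=C(C)C)c(OC)cc3O2)cc1`: 45%
compound 2 `COc1ccc([C@@H]2C/C(=N/OCc3cn(-c4ccc(C(=O)c5ccccc5)cc4)nn3)c3cc(CC=C(C)C)c(OC)cc3O2)cc1`: 34%
compound 3 `COc1cc2c(cc1CC1OC1(C)C)C(=O)C[C@@H](c1ccc(O)cc1)O2`: 79%

In this assay, compound 2 stands lowest of the three at 34%. Its nearest neighbour, compound 1, reads 45%, and compound 3 reads 79%. Both gaps lie beyond the scatter.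

Compound 4 `COc1ccc([C@@H]2C/C(=N/OCc3cn(-c4ccc(C(N)=O)cc4)nn3)c3cc(CC=C(C)C)c(OC)cc3O2)cc1` keeps the rest of compound 2 and carries one change: amino in place of phenyl on a carbonyl carbon. This is amino in place of phenyl on a carbonyl carbon, or benzoyl to carbamoyl when cut one bond further out.

Going by the values given here, no measured pair isolates this change, so the direction is weakly supported. Among the compounds with values here, the only guide is that compound 2 at 34% already sits low, while its nearest neighbour, compound 1, reads 45%. A small upward move in this assay, possibly none beyond the scatter, is the expectation. The step expected is a number 4 percentage points higher from compound 2 to compound 4 (within the scatter). For compound 4 the estimated value is 38%, with an expected range of 24% to 54%.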

Compound 4, percent growth inhibition at one concentration: 100%
The estimate for compound 4 lay 62 percentage points below the measured number; the whole stated range lies below it.
By their numbers in this assay, from the lowest: compound 2; then compound 1; then compound 3; then compound 4.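

In this assay, amino in place of phenyl on a carbonyl carbon, or benzoyl to carbamoyl when cut one bond further out, gives a number 66 percentage points higher from compound 2 to compound 4 (beyond the scatter). Going by these compounds alone, the group on this carbonyl carbon, which the earlier compounds did not vary, is therefore no silent end of the molecule: a single exchange here moves the read-out strongly. The change removes one six-membered aromatic ring of carbon only and adds one hydrogen-bond donor, but this single pair cannot separate those two differences, and no supporting data bear on the reason for the step.

A methyl group or a dimethylamino group on the same carbonyl carbon would help show whether the loss of phenyl or the presence of the amide hydrogens goes with the step. Going by these compounds, a carboxylic acid at this place, and carbamoyl on the core of compound 3, also remain open.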